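Extending a Sulfonamide Nitrogen Toward a Phenylcarbamoyl Group

This account rests on a few compounds, and the source may have more. Where it says the series, first, only, none or still open, it means among the compounds named here.

Three compounds sharing one core have been characterised in a functional assay with Rattus norvegicus as the target; on this read-out lower numbers stand for an effect already at smaller amounts and higher numbers for an effect only at larger amounts of compound. Compound 1 `CNS(=O)(=O)c1ccc2c(c1)C(n1ccccc1=O)=CC(C)(C)O2` gives 138 nM, compound 2 `CC(C)NS(=O)(=O)c1ccc2c(c1)C(n1ccccc1=O)=CC(C)(C)O2` gives 1950 nM, and compound 3 `CN(C)S(=O)(=O)c1ccc2c(c1)C(n1ccccc1=O)=CC(C)(C)O2` gives 95.5 nM. Compound 2 thus carries the highest number of the three: its nearest neighbour is compound 1, and its step away from compound 3 is the largest of the set. The next compound, compound 4 `CC1(C)C=C(n2ccccc2=O)c2cc(S(=O)(=O)NC(=O)Nc3ccccc3)ccc2O1`, differs from compound 2 in one place: phenylcarbamoyl in place of isopropyl on a sulfonamide nitrogen.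

For the measured compounds named here, two measured steps touch the same sulfonamide nitrogen. Going from hydrogen to isopropyl, a 14-fold higher number from compound 1 to compound 2 (1.15 log units; beyond the scatter), while a 20-fold lower number from compound 2 to compound 3 (1.31 log units; beyond the scatter), and a 1.4-fold lower number from compound 1 to compound 3 (0.16 log units; within the scatter). Both large steps are tied to the isopropyl, which leaves here, yet nothing measured tells how a phenylcarbamoyl, with its one hydrogen-bond donor and one hydrogen-bond acceptor, behaves at this nitrogen. Because the isopropyl that departs is the group behind a 14-fold higher number from compound 1 to compound 2 (1.15 log units; beyond the scatter), he expects compound 4 to recover part of that loss, and he estimates a 2.4-fold lower number from compound 2 to compound 4 (0.39 log units; beyond the scatter), though with wide uncertainty. His estimate for compound 4 in this assay is 800 nM, within a range from 150 nM to 5000 nM.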

Compound 4, half-maximal effective concentration: 10000 nM
Estimate against measurement, compound 4: 13-fold (1.10 log units) below; measured number outside the range, above it.
By their numbers in this assay, from the lowest: compounds 3 and 1 (each within the scatter of the next); then compound 2; then compound 4.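

In this assay, taking the isopropyl away from the sulfonamide nitrogen does not by itself bring the number down: with phenylcarbamoyl in its place there is a 5.1-fold higher number from compound 2 to compound 4 (0.71 log units; beyond the scatter). Set against the two compounds with only methyl groups on this nitrogen, the same substituent stands further off, with a 72-fold higher number from compound 1 to compound 4 (1.86 log units; beyond the scatter) and a 100-fold higher number from compound 3 to compound 4 (2.02 log units; beyond the scatter), so compound 4 has the highest number of the four and isopropyl is no longer the least favourable group seen at this position. The compounds shown offer no separate measurement that would account for this rise.

What they leave open is which part of the phenylcarbamoyl goes with the higher number, since its phenyl ring, its carbonyl and its nitrogen hydrogen enter together in one step. An acetyl or a benzyl on the same sulfonamide nitrogen would carry only part of that group, and an ethyl would show how the number moves between methyl and isopropyl.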